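Trimming the alkyne chain of compound 2 to ethynyl

The source may hold more compounds than are shown below. What is called first, only, known or untested is meant among the compounds shown, and "the series" means these compounds.

Of the compounds shown here, two sharing the same core have been measured in an assay on a protein complex for binding affinity to Neuronal acetylcholine receptor; alpha4/beta2 (Rattus norvegicus); a higher number here means a weaker inhibitor, a lower number a stronger inhibitor. Compound 1 `CN1CCC[C@H]1COc1cncc(C#CCCCCF)c1` gives 0.95 nM, and compound 2 `CCCCC#Cc1cncc(OC[C@@H]2CCCN2C)c1` gives 1.4 nM. Going by the values given here, compound 2 carries the higher of the two numbers, but the only measured step, a 1.5-fold higher number from compound 1 to compound 2 (0.17 log units; within the scatter), is within the scatter, so the two compounds cannot be told apart on these data.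

Compound 3 `C#Cc1cncc(OC[C@@H]2CCCN2C)c1` has not yet been measured. It differs from compound 2 by hydrogen in place of butyl on a triple-bonded carbon. Among the compounds with values here, no measured step bears on this change: the step from compound 1 to compound 2 concerns only a fluoro at the far end of the chain, not the chain itself, and it was within the scatter. The expectation therefore rests on the two measured values alone and is correspondingly uncertain. Compound 3 is expected to give about 2 nM, somewhere between 0.5 nM and 10 nM. That estimate means a step of a 1.4-fold higher number from compound 2 to compound 3 (0.15 log units; within the scatter), which is expected to lie within the scatter.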

Compound 3, inhibition constant: 1.6 nM
Estimate against measurement, compound 3: 1.3-fold (0.10 log units) above, and the stated range covers the measured number.
By their numbers in this assay, from the lowest: compounds 1, 2 and 3 (each within the scatter of the next).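

Compound 2 had shown only that a fluoro at the far end of the chain makes no readable difference; now the whole chain turns out to be dispensable in this assay. Hydrogen in place of butyl on a triple-bonded carbon gives a 1.1-fold higher number from compound 2 to compound 3 (0.06 log units; within the scatter), and hydrogen in place of 4-fluorobutyl gives a 1.7-fold higher number from compound 1 to compound 3 (0.23 log units; within the scatter), so the bare ethynyl compound cannot be told apart from either compound carrying a chain. Nothing available here gives a reason for this result.

On these data alone, what remains open is whether this tolerance extends to other groups on the triple-bonded carbon, such as a phenyl ring, or to a chain ending in an amine or a carboxylic acid. These compounds also leave open whether a much longer chain would behave the same way.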